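This account rests on a few compounds, and the source may have more. Where it says the series, first, only, none or still open, it means among the compounds named here.

Compound 1 `COc1ccc2[nH]cc(/C=C/C(=O)c3ccncc3)c2c1` gives 2% in a functional assay on U-251 cells (Homo sapiens) for inhibition, read by colony formation, with stated times of 48 h and 2 weeks, tested at 10 uM (on this read-out higher numbers stand for more inhibition at the one concentration tested (going by the name of the read-out) and lower numbers for less inhibition), and sits at the low end of the three numbers recorded. Its nearest neighbour is compound 2 `O=C(/C=C/c1c[nH]c2ccc(OCc3ccccc3)cc12)c1ccncc1`, which gives 8% in this assay; that change is a number 6 percentage points higher from compound 1 to compound 2 (within the scatter), so the two compounds are not separated by this read-out. Compound 3 `COc1ccc2[nH]cc(/C=C/C(=O)c3cccnc3)c2c1` gives 99% in this assay, and the step of a number 97 percentage points higher from compound 1 to compound 3 (beyond the scatter) is the only one in the set that moves the number at all.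

Compound 4 `COc1ccc2c(c1)c(/C=C/C(=O)c1ccncc1)cn2C` differs from compound 1 in one place: methyl in place of hydrogen on an aromatic nitrogen. Neither measured step touches this position. The step from compound 1 to compound 3 concerns the ring on the carbonyl carbon and says nothing about a change on the aromatic nitrogen. The step from compound 1 to compound 2, an addition at another place on the core, stayed within the scatter, and it offers the nearest parallel. On that basis the step of a number 3 percentage points higher from compound 1 to compound 4 (within the scatter) is expected to be none beyond the scatter. The estimate for compound 4 in this assay is 5%, with a range from 0% to 25%, and the measured number for compound 4 is what remains to be seen.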

Compound 4, a percentage reported as inhibition, at one concentration (the size of the read-out at that concentration, not a potency): 52%
Compound 4: the middle estimate sits 47 percentage points below what was measured; the measured number lies above the stated range.
By their numbers in this assay, from the lowest: compounds 1 and 2 (each within the scatter of the next); then compound 4; then compound 3.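

In this assay, the aromatic nitrogen of the five-membered aromatic ring proves to be a position where a very small change counts: methyl in place of hydrogen, which enters with 1 carbon and no ring, gives a number 50 percentage points higher from compound 1 to compound 4 (beyond the scatter). Going by these compounds alone, the ring on the carbonyl carbon is therefore not the only place where one change moves this read-out, and the core does not respond alike at every place, since the phenyl change on the chain bound to the oxygen gave a number 6 percentage points higher from compound 1 to compound 2 (within the scatter). No measurement available here accounts for the effect of the methyl group at this nitrogen.

Methyl is the only replacement for the hydrogen on this nitrogen among these compounds, so they do not tell whether a longer chain such as propyl, or a chain ending in an amine or a carboxylic acid, would keep, raise or lose the gain. They also leave open whether the methyl change would have any effect alongside pyridin-3-yl on the carbonyl carbon, where compound 3 already gives 99%.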